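The source may hold more compounds than are shown below. What is called first, only, known or untested is meant among the compounds shown, and "the series" means these compounds.

Measured compounds and their values:

Compound 1, `COc1nc(Cl)nc2c1ncn2[C@H]1C[C@H](N=[N+]=[N-])[C@@H](CO)O1`, gives in an ADME assay on Vero cells (Chlorocebus sabaeus) for cytotoxicity, with a stated time of 5 days (on this read-out lower numbers stand for stronger inhibition and higher numbers for weaker inhibition), only the assay limit > 100000 nM.
Compound 2, `C#CCNc1nc(N)nc2c1ncn2[C@H]1C[C@H](N=[N+]=[N-])[C@@H](CO)O1`, gives in this assay only the assay limit > 100000 nM.
Compound 3, `COc1nc(F)nc2c1ncn2[C@H]1C[C@H](N=[N+]=[N-])[C@@H](CO)O1`, gives in this assay only the assay limit > 100000 nM.

Compound 2 therefore stands at a limit, not at a number, and the same holds for the two other compounds measured alongside it, as the limit of > 100000 nM in this assay, at which 3 of the 3 values shown sit, records. Among the measured compounds shown here, the one step between measured compounds, a step that the two limits leave unreadable from compound 1 to compound 3, runs between two limits and its size cannot be read. For the measured compounds named here, no measured step bears directly on the change in question.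

Compound 4, `C=CCNc1nc(N)nc2c1ncn2[C@H]1C[C@H](N=[N+]=[N-])[C@@H](CO)O1`, differs from compound 2 by vinyl in place of ethynyl on a saturated chain carbon bound to a nitrogen on an aromatic ring. With every shown value sitting at the limit and no readable step to draw on, the expected step that the limit leaves unreadable from compound 2 to compound 4 is none that could be distinguished, and compound 4 is expected most probably to return the limit again. The estimate for compound 4 in this assay is 150000 nM, with a range from 50000 nM to 500000 nM.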

Compound 4, half-maximal inhibitory concentration: > 100000 nM
Compound 4 gave a limit, no number; the forecaster's own chance of this, stated with the estimate: 85%; the middle value does not contradict the limit.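

No step can be read from compound 2 to compound 4, since both stand at a limit and not at a number: the limit of > 100000 nM in this assay, at which 4 of the 4 values shown sit.

The compounds shown leave open where any of them would reach half-maximal inhibition in this assay, and whether propargylamino and allylamino differ there at all.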